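Chroman amide series: amine replacement at the carbonyl

The source may hold more compounds than are shown below. What is called first, only, known or untested is meant among the compounds shown, and "the series" means these compounds.

Measured compounds in a functional assay (brain) for inhibition, with Rattus norvegicus as the target; on this read-out lower numbers stand for stronger inhibition and higher numbers for weaker inhibition:
- compound 1, `COc1ccccc1N1CCN(C(=O)C2(C)CCc3c(C)c(O)c(C)c(C)c3O2)CC1`: 15000 nM
- compound 2, `Cc1c(C)c2c(c(C)c1O)CCC(C)(C(=O)N1CCN(c3ccc(Cl)cc3)CC1)O2`: 800 nM
- compound 3, `Cc1c(C)c2c(c(C)c1O)CCC(C)(C(=O)N1CCNCC1)O2`: 10000 nM

Compound 3 stands second highest of the three numbers. Its nearest neighbour is compound 1, which lies within the scatter of it (a 1.5-fold lower number from compound 1 to compound 3 (0.18 log units; within the scatter)); its furthest is compound 2, which lies well beyond (a 13-fold higher number from compound 2 to compound 3 (1.10 log units; beyond the scatter)). Within the measured set, only an aromatic group on the amine nitrogen in the ring has moved the number by a large amount, and only in one of the two cases.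

Compound 4, `Cc1c(C)c2c(c(C)c1O)CCC(C)(C(=O)Nc1ccncc1)O2`, is not yet measured. It differs from compound 3 in one place: (pyridin-4-yl)amino in place of piperazin-1-yl on a carbonyl carbon. Going by the values given here, no measured step covers this exchange of the whole ring for an aromatic amine on the carbonyl carbon. The bearing steps are a 13-fold higher number from compound 2 to compound 3 (1.10 log units; beyond the scatter), large, and a 1.5-fold lower number from compound 1 to compound 3 (0.18 log units; within the scatter), within the scatter; together they show that an aromatic group in this region can give a large step or none, so the expected direction is uncertain and a moderate step downward is taken as the working estimate, a 2.0-fold lower number from compound 3 to compound 4 (0.30 log units; within the scatter). Compound 4 is therefore expected to give about 5000 nM, with a range from 1500 nM to 15000 nM.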

Compound 4, half-maximal inhibitory concentration: 2300 nM
Beside the measured number, compound 4's estimate is 2.2-fold (0.34 log units) above it; low and high end bracket the measured number.
By their numbers in this assay, from the lowest: compound 2; then compound 4; then compounds 3 and 1 (each within the scatter of the next).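

In this assay, exchanging the whole amine on the carbonyl carbon gives a 4.3-fold lower number from compound 3 to compound 4 (0.64 log units; beyond the scatter) and so moves the number beyond the scatter, a modest step. Up to this point only the group on the amine nitrogen in the ring had been varied, with one large step for 4-chlorophenyl in compound 2 and none for 2-methoxyphenyl in compound 1. The amine on the carbonyl carbon is therefore a second place in the series where the number responds, and here the change replaces the non-aromatic ring with an aromatic one. No measurement in hand accounts for this step.

Open, going by these compounds, is whether phenylamino or (pyridin-3-yl)amino on the same carbonyl carbon would keep the number of compound 4. Also open, on these data alone, is whether a methyl group in place of the amide hydrogen would alter it.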